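Amide aryl variation on the flavonol series: nitro for methoxy

The source may hold more compounds than are shown below. What is called first, only, known or untested is meant among the compounds shown, and "the series" means these compounds.

Compound 1 `COc1ccc(C(=O)Nc2cccc(-c3oc4cc(-c5ccc(F)cc5)ccc4c(=O)c3O)c2)cc1` is the reference for the amide aryl group. In a functional assay on A549 cells (Homo sapiens) for antiproliferative activity, read by CCK-8 assay, with a stated time of 72 h (a lower number here means a stronger inhibitor, a higher number a weaker inhibitor), compound 1 gives 8700 nM, the lowest of the two numbers recorded, with compound 2 `Cc1cc(C(=O)Nc2cccc(-c3oc4cc(-c5ccc(F)cc5)ccc4c(=O)c3O)c2)ccc1F` closest at 11500 nM in this assay; the step of a 1.3-fold higher number from compound 1 to compound 2 (0.12 log units; within the scatter) separates them. Compound 3 `O=C(Nc1cccc(-c2oc3cc(-c4ccc(F)cc4)ccc3c(=O)c2O)c1)c1cnc(Cl)nc1Cl` reaches only the limit > 100000 nM in this assay (the limit of > 100000 nM in this assay, at which 1 of the 3 values shown sits). The steps of an at least 11-fold higher number from compound 1 to compound 3 (1.06 log units; beyond the scatter) and an at least 8.6-fold higher number from compound 2 to compound 3 (0.93 log units; beyond the scatter) show the loss on moving from a substituted phenyl to the dichloropyrimidinyl amide.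

Compound 4 `O=C(Nc1cccc(-c2oc3cc(-c4ccc(F)cc4)ccc3c(=O)c2O)c1)c1ccc([N+](=O)[O-])cc1` differs from compound 1 by nitro in place of methoxy on an aromatic carbon. The change stays on a phenyl amide, so the relevant comparison is the phenyl-to-phenyl step a 1.3-fold higher number from compound 1 to compound 2 (0.12 log units; within the scatter), which was within the scatter, whereas the large steps to compound 3 involved a different ring. A small step is therefore expected, with no firm direction. Compound 4 is estimated at 12000 nM in this assay, between 4500 nM and 35000 nM, meaning an expected step of a 1.4-fold higher number from compound 1 to compound 4 (0.14 log units; within the scatter).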

Compound 4, half-maximal inhibitory concentration: 2440 nM
Compound 4: the middle estimate sits 4.9-fold (0.69 log units) above what was measured; the measured number lies below the stated range.
By their numbers in this assay, from the lowest: compound 4; then compounds 1 and 2 (each within the scatter of the next). At a limit, above all of these: compound 3.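

Substitution on the amide phenyl is not neutral in this assay: nitro for methoxy, para to a large group, gives a 3.6-fold lower number from compound 1 to compound 4 (0.55 log units; beyond the scatter), and the 4-nitrophenyl amide gives a 4.7-fold lower number from compound 2 to compound 4 (0.67 log units; beyond the scatter), whereas the earlier phenyl-to-phenyl step stayed within the scatter. Against the dichloropyrimidinyl amide, the 4-nitrophenyl group gives an at least 40-fold lower number from compound 3 to compound 4 (1.61 log units; beyond the scatter), which widens the spread across the amide aryl groups. The value for compound 3 in that step is a limit, not a number: the limit of > 100000 nM in this assay, at which 1 of the 4 values shown sits.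

With nitro as the only group shown to give this gain over methoxy on this carbon, the gain cannot yet be tied to nitro in particular; a nitrile, a trifluoromethyl or an amine at the same place would test that. Going by these compounds, whether nitro keeps the gain elsewhere on the phenyl ring also remains open.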